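From methyl to chloro on an inactive compound

This account rests on a few compounds, and the source may have more. Where it says the series, first, only, none or still open, it means among the compounds named here.

- Compound 1 `Cc1ccccc1NNC(=O)c1ccc(NS(=O)(=O)c2cnc(O)nc2O)cc1`: > 20000 nM (a limit)
- Compound 2 `Cc1cccc(NNC(=O)c2cccc(NS(=O)(=O)c3cnc(O)nc3O)c2)c1`: > 20000 nM (a limit)

In a functional assay on MDA-MB-231 cells (Homo sapiens) for antiproliferative activity, read by MTT assay, with a stated time of 24 h (on this read-out higher numbers stand for weaker inhibition and lower numbers for stronger inhibition), compound 2 gives > 20000 nM, which is a limit and not a number. Compound 2 thus stands at the limit of > 20000 nM in this assay, at which 2 of the 2 values shown sit. Compound 3 `O=C(NNc1cccc(Cl)c1)c1cccc(NS(=O)(=O)c2cnc(O)nc2O)c1` differs from compound 2 in one place: chloro in place of methyl on an aromatic carbon. Among the compounds with values here, no measured pair shows what chloro in place of methyl on an aromatic carbon does, so in this assay no change beyond the scatter is expected, in either direction. The estimated change is a number no higher from compound 2 to compound 3 (the limit leaves the size open). Compound 3 is expected near 20000 nM, with an estimated range of 7000 nM to 40000 nM.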

Compound 3, half-maximal inhibitory concentration: 7760 nM
Compound 3: middle estimate off by 2.6-fold (0.41 log units), on the high side; measured number inside the range.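

In this assay, going from 3-methylphenyl to 3-chlorophenyl gives an at least 2.5-fold lower number from compound 2 to compound 3 (0.41 log units; beyond the scatter), so this single swap on the aromatic carbon moves the read-out to a real number for the first time among the compounds shown. The full size of the step stays open because compound 2 carries a limit and not a number: the limit of > 20000 nM in this assay, at which 2 of the 3 values shown sit.

From the compounds shown here alone, it remains open whether bromo, methoxy or an amine on this carbon would lower the number further. Whether chloro would act the same way on the core of compound 1 is also unknown.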